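The source may hold more compounds than are shown below. What is called first, only, known or untested is meant among the compounds shown, and "the series" means these compounds.

Compound 1 `Cc1ccc(C#N)c(OC(C)(C)C2OCC(C/C=C\CCC(=O)O)C(c3cccnc3)O2)c1` gives 50 nM in an assay for inhibition of Thromboxane-A synthase (Homo sapiens), using microsomes (a lower number here means a stronger inhibitor, a higher number a weaker inhibitor), the highest of the three numbers recorded, though each gap to the others is within the scatter. Compound 2 `COc1ccc(OC(C)(C)C2OCC(C/C=C\CCC(=O)O)C(c3cccnc3)O2)c([N+](=O)[O-])c1` gives 37 nM in this assay, and compound 3 `COc1ccc(SC(C)(C)C2OCC(C/C=C\CCC(=O)O)C(c3cccnc3)O2)c([N+](=O)[O-])c1` gives 40 nM. Compound 4 `CC(C)(Cc1ccccc1)C1OCC(C/C=C\CCC(=O)O)C(c2cccnc2)O1` differs from compound 1 in that (a group of 7 heavy atoms (7 carbon; one six-membered aromatic ring of carbon only) in place of a group of 10 heavy atoms (8 carbon, 1 nitrogen, 1 oxygen; one six-membered aromatic ring of carbon only), on a saturated chain carbon bound to two saturated chain carbons and a saturated ring carbon). Among the measured compounds shown here, the one measured step that touches this region, a 1.4-fold lower number from compound 1 to compound 2 (0.13 log units; within the scatter), exchanged only the aromatic part while keeping the oxygen on the saturated carbon, and compounds 2 and 3 hold values within the scatter of each other. For the measured compounds named here, no measured pair removes the oxygen or the nitrile, so the expectation rests on the tolerance seen so far, with added uncertainty. Compound 4 is therefore expected to show a 1.6-fold higher number from compound 1 to compound 4 (0.20 log units; within the scatter), giving an estimate of 80 nM with a range from 25 nM to 300 nM.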

Compound 4, half-maximal inhibitory concentration: 12 nM
For compound 4 the middle estimate is 6.7-fold (0.82 log units) above the measured one, outside the stated range (below it).
By their numbers in this assay, from the lowest: compound 4; then compounds 2, 3 and 1 (each within the scatter of the next).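

In this assay, benzyl in place of the larger group of compound 1 gives a 4.2-fold lower number from compound 1 to compound 4 (0.62 log units; beyond the scatter), the only step shown here that lies beyond the scatter. This position therefore responds to the change, and inhibition does not depend on the departing group's oxygen or nitrile, since benzyl has neither. No evidence at hand accounts for this step. From the compounds shown here alone, the oxygen, nitrile and methyl leave together, so their separate contributions stay open. Going by these compounds, whether a longer chain or an amine on the aromatic ring would keep this level also stays open.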